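Swapping a butylamide for a morpholine amide in paw-edema inhibition

The source may hold more compounds than are shown below. What is called first, only, known or untested is meant among the compounds shown, and "the series" means these compounds.

Measured compounds:
compound 1, `CNC(=O)CC1CCc2cc(OC)c(OC)cc21`: 15.6%
compound 2, `COc1cc2c(cc1OC)C(CC(=O)NC(C)C)CC2`: 31.3%
compound 3, `CCCCNC(=O)CC1CCc2cc(OC)c(OC)cc21`: 31.3%

In a functional assay on the whole organism (strain Wistar) for inhibition, with Rattus norvegicus as the target, read by paw edema, with stated times of 60 min and 1 h, at a dose of 100 mg/kg by the oral route (on this read-out higher numbers stand for more inhibition at the one dose given (going by the name of the read-out) and lower numbers for less inhibition), compound 3 stands level with compound 2 at the digits printed, the two sharing the highest number of the three, while compound 1 lies lowest: the step of a number 15.7 percentage points higher from compound 1 to compound 3 (beyond the scatter) is beyond the scatter, and so is a number 15.7 percentage points higher from compound 1 to compound 2 (beyond the scatter). Between compound 2 and compound 3 the step of no change at the digits printed from compound 2 to compound 3 (within the scatter) is within the scatter.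

Compound 4, `COc1cc2c(cc1OC)C(CC(=O)N1CCOCC1)CC2`, is not yet measured. It differs from compound 3 by morpholin-4-yl in place of butylamino on a carbonyl carbon. Among the compounds with values here, none of the measured steps exchanges an amide bearing a hydrogen for one with a ring; the steps from compound 1 only show that enlarging the group on the amide nitrogen raised inhibition, and the step from compound 2 to compound 3 shows that two groups of similar size gave the same number. With no direct guide, the expected step is a number 3.3 percentage points lower from compound 3 to compound 4 (within the scatter), within the scatter. Compound 4 is therefore estimated to give 28%, between 12% and 45%.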

Compound 4, a percentage reported as inhibition, in the whole organism at one dose (the size of the read-out at that dose, not a potency): 15.6%
Estimate against measurement, compound 4: 12.4 percentage points above, and the stated range covers the measured number.
By their numbers in this assay, from the lowest: compounds 1 and 4 (each within the scatter of the next); then compounds 2 and 3 (each within the scatter of the next).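

In this assay, the rise seen when methylamino gave way to larger open groups on the amide nitrogen does not extend to every larger group at this carbonyl carbon: morpholin-4-yl in place of butylamino gives a number 15.7 percentage points lower from compound 3 to compound 4 (beyond the scatter), and morpholin-4-yl in place of isopropylamino gives a number 15.7 percentage points lower from compound 2 to compound 4 (beyond the scatter). Against the smallest group the ring gives no change at the digits printed from compound 1 to compound 4 (within the scatter), so a group with more heavy atoms than butylamino can still leave the number where methylamino left it. No available measurement explains this result.

This change removes the amide hydrogen and also brings in a ring and a ring oxygen, and these compounds cannot tell those parts apart. Piperidin-1-yl would keep the ring without the oxygen, while 2-methoxyethylamino would keep the amide hydrogen and an oxygen without the ring.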